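This account rests on a few compounds, and the source may have more. Where it says the series, first, only, none or still open, it means among the compounds named here.

In a functional assay on the whole organism with Rattus norvegicus as the target (on this read-out higher numbers stand for larger maximal responses and lower numbers for smaller maximal responses), compound 3 `Nc1ncnc2c1ncn2C1O[C@H](CO)[C@H](O[C@@H]2OC(CO)[C@H](OP(=O)(O)O)C(OP(=O)(O)O)[C@@H]2O)[C@@H]1OP(=O)(O)O` gives 35%, and this lies within the scatter of both companions: compound 2 `COc1ncnc2c1ncn2C1O[C@H](CO)[C@H](O[C@@H]2OC(CO)[C@H](OP(=O)(O)O)C(OP(=O)(O)O)[C@@H]2O)[C@@H]1OP(=O)(O)O` gives 34% and compound 1 `CNc1nc(OC)nc2c1ncn2C1O[C@H](CO)[C@H](O[C@@H]2OC(CO)[C@H](OP(=O)(O)O)C(OP(=O)(O)O)[C@@H]2O)[C@@H]1OP(=O)(O)O` gives 34%. Among the compounds with values here, the one single step among them, a number 1 percentage points higher from compound 2 to compound 3 (within the scatter), changed nothing beyond the scatter. Compound 4 `O=P(O)(O)OC1[C@@H](OP(=O)(O)O)C(CO)O[C@@H](O[C@@H]2[C@H](OP(=O)(O)O)C(n3cnc4c(NC5CCCC5)ncnc43)O[C@@H]2CO)[C@H]1O` differs from compound 3 by cyclopentyl in place of hydrogen on a nitrogen on an aromatic ring. Within the data shown here, no measured step covers this substitution; compound 1 differs from compound 3 in more than one place, and its value sits alongside that of compound 3, so the three numbers give no sign that a change on this part of the core moves the response. The expectation is therefore a number 1 percentage points lower from compound 3 to compound 4 (within the scatter), a step that stays within the scatter. For compound 4 the estimate in this assay is 34%, between 20% and 48%.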

Compound 4, largest response reached (reported as maximal response), in percent of the reference or control that the assay uses: 35%
The estimate for compound 4 lay 1 percentage points below the measured number; measured number inside the range.
By their numbers in this assay, from the lowest: compounds 1, 2, 3 and 4 (each within the scatter of the next).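

Within the data shown here, compound 4 gives the first direct reading at this position: in this assay putting cyclopentyl in place of hydrogen on a nitrogen on an aromatic ring gives no change at the digits printed from compound 3 to compound 4 (within the scatter) and so leaves the response unmoved. The exchange of methoxy for cyclopentylamino gives a number 1 percentage points higher from compound 2 to compound 4 (within the scatter) and likewise stays inside the scatter. Nothing available explains this flat response.

As far as these compounds go, whether a longer alkyl chain, a benzyl group or a carboxylic acid on this nitrogen would move the response beyond the scatter remains open.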